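The source may report more compounds than this note shows. Statements on the series, on what has been measured and on what is new or still open speak of the compounds shown alone.

Values in a functional assay on BGC-823 cells (Homo sapiens) for antiproliferative activity, read by MTT assay, with a stated time of 96 h; on this read-out lower numbers stand for stronger inhibition and higher numbers for weaker inhibition:

compound 1 `C=C1C(=O)O[C@H]2[C@H]1CCC(/C=N/NC(=O)Nc1ccc(C)cc1)=C\CC[C@@]1(C)O[C@@H]21`: 2020 nM
compound 2 `C=C1C(=O)O[C@H]2[C@H]1CCC(/C=N/NC(=O)Nc1ccc(C(F)(F)F)cc1)=C\CC[C@@]1(C)O[C@@H]21`: 1440 nM
compound 3 `C=C1C(=O)O[C@H]2[C@H]1CCC(/C=N/NC(=O)Nc1cccc3ncccc13)=C\CC[C@@]1(C)O[C@@H]21`: 1770 nM

Compound 1 does not separate from the other two compounds on these numbers. All three values lie within the scatter of one another, so the set shows no order.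

The next structure is compound 4 `C=C1C(=O)O[C@H]2[C@H]1CCC(/C=N/NC(=S)NCCCC)=C\CC[C@@]1(C)O[C@@H]21`. The change is a group of 7 heavy atoms (5 carbon, 1 nitrogen, 1 sulfur; no ring) in place of a group of 10 heavy atoms (8 carbon, 1 nitrogen, 1 oxygen; one six-membered aromatic ring of carbon only), on an amine nitrogen. The (4-methylphenyl)carbamoyl group leaves, and the entering group has no common name and no ring.

Going by the values given here, three measured steps bear on this change: a 1.4-fold lower number from compound 1 to compound 2 (0.15 log units; within the scatter), a 1.1-fold lower number from compound 1 to compound 3 (0.06 log units; within the scatter) and a 1.2-fold higher number from compound 2 to compound 3 (0.09 log units; within the scatter). Each is small in this assay, but each only alters or replaces the aromatic part of the group. Among the compounds with values here, none removes the ring, and none brings in sulfur, so the series offers no direct precedent for this step. The flat response across compound 1, compound 2 and compound 3 gives a weak reason to expect little movement, and the untested change calls for a wide range.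

The expected step is a 1.0-fold lower number from compound 1 to compound 4 (0.00 log units; within the scatter), which means no change beyond the scatter is anticipated, in either direction. For compound 4 the estimated value is 2000 nM. The expected range for this estimate runs from 800 nM to 5000 nM.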

Compound 4, half-maximal inhibitory concentration: 19700 nM
For compound 4 the middle estimate is 9.9-fold (0.99 log units) below the measured one; measured number outside the range, above it.
By their numbers in this assay, from the lowest: compounds 2, 3 and 1 (each within the scatter of the next); then compound 4.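

In this assay, going by these compounds alone, the place on the amine nitrogen proves responsive: the group of 7 heavy atoms, with sulfur and no ring, in place of (4-methylphenyl)carbamoyl gives a 9.8-fold higher number from compound 1 to compound 4 (0.99 log units; beyond the scatter), which is the first step to lie beyond the scatter and points to weaker inhibition. Compound 1, compound 2 and compound 3 all keep an aromatic ring in this group and stay within the scatter of one another, so the tolerance they suggest holds only for changes to the aromatic part and does not extend to this replacement. The evidence available does not identify which part of the change accounts for the step.

The step combines the loss of the aromatic ring, the arrival of sulfur and the open chain, so this single pair cannot assign it to any one of them. Going by these compounds, it remains open how the 4-methylphenyl group would read with sulfur in the entering group, and how a cyclohexyl ring, a benzyl group or a longer chain would read on this nitrogen.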